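A few compounds are considered here, and "the series" means these few. Any claim that something is new, unique, unknown or untested is made for them only; others in the source may bear on it.

Working notes on the series in a functional assay on CAKI-1 cells (Homo sapiens) for cytotoxicity, read by sulforhodamine B assay, with a stated time of 48 h; on this read-out higher numbers stand for weaker inhibition of growth and lower numbers for stronger inhibition of growth. Of the compounds shown here, two have numbers so far. Compound 1 `ClCc1ccccc1Cn1cnc2c(Cl)nc(Cl)nc21` gives 360 nM in this assay, and compound 2 `ClCc1ccc(Cn2cnc3c(Cl)nc(Cl)nc32)cc1` gives 9120 nM. For the measured compounds named here, compound 1 stands lowest of the two, with compound 2 as its nearest neighbour at a markedly higher number, a gap well beyond the scatter; the two differ in where the chloromethyl arm sits on the benzyl group, a pair for which no single step is worked out here, so only the two values themselves are on record.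

The next compound, compound 3 `Nc1nc(Cl)c2ncn(Cc3ccccc3CCl)c2n1`, keeps the benzyl arrangement of compound 1 and changes the core: amino in place of chloro on an aromatic carbon. Going by the values given here, no measured pair in this set shows the effect of such a change on the core, so the size of the step rests on judgement alone. The arm that the two measured compounds share is untouched, which argues against a large move; still, some loss is anticipated, and the expected step is a 2.8-fold higher number from compound 1 to compound 3 (0.44 log units; beyond the scatter). Compound 3 is accordingly estimated at 1000 nM in this assay, within a range from 250 nM to 4000 nM.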

Compound 3, concentration for 50% growth inhibition: 6610 nM
Estimate against measurement, compound 3: 6.6-fold (0.82 log units) below; the measured number lies above the stated range.
By their numbers in this assay, from the lowest: compound 1; then compounds 3 and 2 (each within the scatter of the next).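

In this assay the aromatic carbon between two ring nitrogen atoms proves sensitive to change: amino in place of chloro gives an 18-fold higher number from compound 1 to compound 3 (1.26 log units; beyond the scatter) while the chloromethyl benzyl arm stays as it is. Until now only the place of the chloromethyl arm had been seen to move the number, so the core now stands as a second place where a single change counts, and in both cases the number rises from that of compound 1 by more than the scatter. Nothing on hand gives a measured property that bears on this step, so the result stands as an observation without an explanation.

The single replacement leaves open whether the loss belongs to amino in particular or to any departure from chloro on this carbon, which a methoxy group, a methylamino group or plain hydrogen there would help to settle. Also open, from the compounds shown here alone, are whether the step keeps its size with the chloromethyl arm placed as in compound 2, and what amino would do in place of the other chloro group on the core.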